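The compounds below may be only part of what the source reports. "The series", "measured", "known", "first", "only" and "open" are said of these compounds alone.

Measured so far:
Compound 1 `CCOC(=O)N1CCC(=NNC(=O)c2ccc([N+](=O)[O-])cc2)CC1`: 10900 nM
Compound 2 `CCOC(=O)N1CCC(=NNC(=O)c2ccc([N+](=O)[O-])cc2[N+](=O)[O-])CC1`: 117000 nM
Compound 3 `O=C(NN=C1CC(c2ccccc2)NC(c2ccccc2)C1)c1ccc([N+](=O)[O-])cc1`: 170000 nM

Compound 1 and compound 2 share one core, while compound 3 is built on a different core; the difference between the two cores is not broken down here. In a functional assay, read by spectrophotometry (on this read-out lower numbers stand for stronger inhibition and higher numbers for weaker inhibition), compound 1 gives 10900 nM. Compound 2 differs from compound 1 in a single place, (nitro in place of hydrogen on an aromatic carbon), and in this assay compound 2 gives 117000 nM. That one change made an 11-fold higher number from compound 1 to compound 2 (1.03 log units; beyond the scatter). In this assay compound 3 gives 170000 nM, a number close to that of compound 2 and well apart from that of compound 1.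

Compound 4 `O=C(NN=C1CC(c2ccccc2)NC(c2ccccc2)C1)c1ccc([N+](=O)[O-])cc1[N+](=O)[O-]` has not yet been measured. It differs from compound 3 in the same way, (nitro in place of hydrogen on an aromatic carbon), at a place described in the same words as before, so this is the same change carried onto the other core. Going by the values given here, only one earlier example of it exists. Because compound 2 showed an 11-fold higher number from compound 1 to compound 2 (1.03 log units; beyond the scatter), the step expected for compound 4 is a 7.1-fold higher number from compound 3 to compound 4 (0.85 log units; beyond the scatter). Compound 4 is thus estimated at 1200000 nM, expected to fall between 300000 nM and 5000000 nM.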

Compound 4, half-maximal inhibitory concentration: 19300 nM
Beside the measured number, compound 4's estimate is 62-fold (1.79 log units) above it, and the stated range ends above it.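

In this assay, the nitro group entering on the aromatic ring gives an 8.8-fold lower number from compound 3 to compound 4 (0.94 log units; beyond the scatter), so on this core the change runs the opposite way to the step seen on the other core. The two steps disagree by far more than repeated measurements would explain: the same change on two cores in this assay, an 11-fold higher number (1.03 log units; beyond the scatter) from compound 1 to compound 2 and an 8.8-fold lower number (0.94 log units; beyond the scatter) from compound 3 to compound 4, 95-fold (1.98 log units) apart, beyond the scatter of two such steps This shows that, for these two pairs, the size and even the direction of the step depend on the core carrying the change, so a step read on one core could not be transferred to the other; it does not show why the cores behave differently, and with one pair on each core it gives no general rule.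

The compounds shown leave open whether another group in the same place, such as an amine or a carboxylic acid, would also move in opposite directions on the two cores. They also leave open which part of the difference between the cores sets the direction of the step.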